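Notes on the step from compound 3 to compound 4

The source may hold more compounds than are shown below. What is called first, only, known or untested is meant among the compounds shown, and "the series" means these compounds.

Values in a functional assay (aorta) with Rattus norvegicus as the target; on this read-out lower numbers stand for an effect already at smaller amounts and higher numbers for an effect only at larger amounts of compound:
- compound 1 `CNC(=N)Nc1nc(-c2ccc(OC)cc2)c(-c2ccc(OC)cc2)s1`: 1.2 uM
- compound 2 `COc1ccc(-c2nc(CN(C)C)sc2-c2ccc(OC)cc2)cc1`: 8.4 uM
- compound 3 `CNC(=O)NCc1nc(-c2ccc(OC)cc2)c(-c2ccc(OC)cc2)s1`: 15 uM
- compound 4 `COc1ccc(-c2nc(C(=O)N=C(N)N)sc2-c2ccc(OC)cc2)cc1`: not yet measured

Compound 3 sits with compound 2, the data showing a 1.8-fold higher number from compound 2 to compound 3 (0.25 log units; within the scatter). Compound 1 stands apart from it, with a 13-fold higher number from compound 1 to compound 3 (1.10 log units; beyond the scatter).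

The next comparison is a group of 6 heavy atoms (2 carbon, 3 nitrogen, 1 oxygen; no ring) in place of a group of 6 heavy atoms (3 carbon, 2 nitrogen, 1 oxygen; no ring), on an aromatic carbon. The ((methylcarbamoyl)amino)methyl group leaves and a group with no common name enters, on an aromatic carbon of a five-membered aromatic ring with 1 nitrogen and 1 sulfur. The count of heavy atoms stays the same, but the make-up does not.

Within the data shown here, no measured step makes this exact exchange, so the evidence is indirect. Of the measured groups, the entering one reads closest to that on compound 1. Moving away from compound 1 gave a 7.0-fold higher number from compound 1 to compound 2 (0.85 log units; beyond the scatter) and a 13-fold higher number from compound 1 to compound 3 (1.10 log units; beyond the scatter), both beyond the scatter, so the group on compound 1 is the one measured change that clearly matters here. The resemblance is only partial, so a full return to the number of compound 1 is not assumed.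

In this assay the expected change is a partial return, an estimated 3.8-fold lower number from compound 3 to compound 4 (0.57 log units; beyond the scatter). For compound 4 the estimated value is 4 uM, with an expected range of 1 uM to 15 uM.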

Compound 4, concentration for half-maximal effect: > 100 uM
Compound 4: only a limit was reported; the forecaster's own chance of this, stated with the estimate: 3%; middle value at least 25-fold (1.39 log units) from the limit.
By their numbers in this assay, from the lowest: compound 1; then compounds 2 and 3 (each within the scatter of the next). At a limit, above all of these: compound 4.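

In this assay compound 4 gives > 100 uM, which is a limit of the assay and not a number. Measured against it, the group on the aromatic carbon of the five-membered aromatic ring with 1 nitrogen and 1 sulfur gives an at least 6.6-fold higher number from compound 3 to compound 4 (0.82 log units; beyond the scatter), an at least 11-fold higher number from compound 2 to compound 4 (1.07 log units; beyond the scatter) and an at least 83-fold higher number from compound 1 to compound 4 (1.92 log units; beyond the scatter), so this position can do more than shift the number within the narrow span set by compounds 1, 2 and 3. The counts of heavy atoms, hydrogen-bond donors and hydrogen-bond acceptors stay the same between compound 3 and compound 4, and the group of compound 4 shares its carbon and nitrogen counts with none of the others except in nitrogen with compound 1, so neither those counts nor that nitrogen count alone sets the read-out in this series.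

How far compound 4 lies past its limit stays open, and the compounds shown give no cause for the step. A carboxylic acid or a primary amide on the same aromatic carbon, or a primary amine on a longer chain there, would help show which part of the entering group goes with the change.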